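The source may report more compounds than this note shows. Statements on the series, on what has been measured and on what is new or still open speak of the compounds shown alone.

Compound 2, `Nc1ncc(-c2ccc(C(=O)N3CCC(O)C3)cc2)nc1-c1ccc(C(F)(F)F)cc1`, carries a shared core with compound 1, `Nc1ncc(-c2ccc(C(=O)N3CCC(N)C3)cc2)nc1-c1ccc(C(F)(F)F)cc1`. In a physicochemical assay for solubility, read by HPLC, using the shake flask method, with a stated time of 2 h, at pH 2 (a lower number here means a less soluble compound, a higher number a more soluble compound), compound 1 gives 165000 nM, and compound 2 gives 129000 nM, the lower of the two numbers, though the step of a 1.3-fold lower number from compound 1 to compound 2 (0.11 log units; within the scatter) lies within the scatter, so neither compound can be ranked above the other.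

Compound 3, `Nc1ncc(-c2ccc(C(=O)N3CCC(N)CC3)cc2)nc1-c1ccc(C(F)(F)F)cc1`, is not yet measured. It differs from compound 2 in one place: 4-aminopiperidin-1-yl in place of 3-hydroxypyrrolidin-1-yl on a carbonyl carbon. Going by the values given here, the only measured step that bears on it is a 1.3-fold lower number from compound 1 to compound 2 (0.11 log units; within the scatter), which also exchanges an amino for a hydroxy on a saturated ring and stays within the scatter; no measured pair speaks to the change of ring size. Compound 3 is therefore expected to show a step of a 1.3-fold higher number from compound 2 to compound 3 (0.12 log units; within the scatter) that is not beyond the scatter. The expected value for compound 3 in this assay is 170000 nM, with a range from 80000 nM to 360000 nM.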

Compound 3, solubility: 200000 nM
For compound 3 the middle estimate is 1.2-fold (0.07 log units) below the measured one; low and high end bracket the measured number.
By their numbers in this assay, from the lowest: compounds 2, 1 and 3 (each within the scatter of the next).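

In this assay, going by these compounds alone, the exchange of ring on the carbonyl carbon can now be read for the first time: the step of a 1.2-fold higher number from compound 1 to compound 3 (0.08 log units; within the scatter) keeps an amino group while 4-aminopiperidin-1-yl replaces 3-aminopyrrolidin-1-yl, and it lies within the scatter. The step of a 1.6-fold higher number from compound 2 to compound 3 (0.19 log units; within the scatter) changes the ring and the group on it together, and it too stays within the scatter. Among these three compounds, neither the five-membered nor the six-membered ring separates from the other at this position, and no data here offer an explanation for this result.

It remains open whether a 4-hydroxypiperidin-1-yl group would also stay within the scatter of these compounds. The same question applies to a carboxylic acid or a longer chain on this ring.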